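This account rests on a few compounds, and the source may have more. Where it says the series, first, only, none or still open, it means among the compounds named here.

Measured so far in a functional assay on G-361 cells (Homo sapiens) for antiproliferative activity, with a stated time of 72 h; a higher number here means a weaker inhibitor, a lower number a stronger inhibitor:
- compound 1 `OC[C@H]1O[C@@H](n2cnc3c(NCc4ccccc4F)ncnc32)[C@H](O)[C@@H]1O`: "not determined" (no result reported)
- compound 2 `OC[C@H]1O[C@@H](n2cnc3c(NCc4ccccc4Br)ncnc32)[C@H](O)[C@@H]1O`: > 166000 nM
- compound 3 `OC[C@H]1O[C@@H](n2cnc3c(NCc4ccc(F)cc4F)ncnc32)[C@H](O)[C@@H]1O`: > 166000 nM

Compound 3 gives > 166000 nM, which is a limit and not a number. Compound 2 gives > 166000 nM, also a limit. Within the data shown here, the series so far offers only (the limit of > 166000 nM in this assay, at which 2 of the 3 values shown sit), and compound 1 adds no result.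

Compound 4 `OC[C@H]1O[C@@H](n2cnc3c(NCc4ccc(F)c(F)c4F)ncnc32)[C@H](O)[C@@H]1O` differs from compound 3 by fluoro in place of hydrogen on an aromatic carbon. This is fluoro in place of hydrogen on an aromatic carbon, ortho to two fluoro groups and meta to a large group, taking 2,4-difluorophenyl to 2,3,4-trifluorophenyl.

Among the measured compounds shown here, the only measured step bearing on this is a step that the two limits leave unreadable from compound 2 to compound 3, so it gives no size to carry over. With no readable step available, the most likely outcome in this assay is another limit, with at best a modest move toward a stronger inhibitor. The expected change is an at least 1.2-fold lower number from compound 3 to compound 4 (0.10 log units; that floor lies within the scatter), and this figure is only an estimate. For compound 4 the estimated value is 130000 nM, with an expected range of 20000 nM to 166000 nM.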

Compound 4, half-maximal inhibitory concentration: > 166000 nM
Compound 4: no number, only a limit (the forecaster's own chance of this, stated with the estimate: 65%); middle value at least 1.2-fold (0.10 log units) from the limit.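

In this assay compound 4 gives > 166000 nM, a limit and not a number. Among these compounds, no step among compound 2, compound 3 and compound 4 can be read. Whether any of these phenyl changes alters activity stays open, with the series resting on one value: the limit of > 166000 nM in this assay, at which 3 of the 4 values shown sit.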